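The source may hold more compounds than are shown below. What is called first, only, known or untested is meant among the compounds shown, and "the series" means these compounds.

Compounds measured so far:
- Compound 2, `COc1cc2c(Oc3ccc(NC(=O)c4nccc(-c5ccc(C)cc5)n4)cc3F)ccnc2cc1OCCCN1CCCCC1`: 1140 nM
- Compound 1, `COc1ccc(-c2ccnc(C(=O)Nc3ccc(Oc4ccnc5cc(OCCCN6CCCC6)c(OC)cc45)c(F)c3)c2)c(OC)c1`: "not determined" (no result reported)

Two compounds were tested in a functional assay on U-87MG ATCC cells (Homo sapiens) for cytotoxicity, read by MTT assay, with a stated time of 72 h; on this read-out higher numbers stand for weaker inhibition and lower numbers for stronger inhibition. For compound 1 no number was reported, so everything known here rests on compound 2, which in this assay gives 1140 nM. Within the data shown here, this is the only value in hand, so compound 2 can be placed neither as strong nor as weak among the others; it simply sets the reference point.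

Compound 3, `COc1cc2c(Oc3ccc(NC(=O)c4nccc(-c5ccc(F)cc5F)n4)cc3F)ccnc2cc1OCCCN1CCCCC1`, has not yet been measured. It differs from compound 2 in one place: 2,4-difluorophenyl in place of 4-methylphenyl on an aromatic carbon. Among the measured compounds shown here, no measured pair in this set shares this kind of exchange, so there is no measured step to lean on. For the measured compounds named here, with only one number available, the most reasonable expectation is a change that stays within the usual scatter, in no particular direction.

Compound 3 is therefore expected to come out close to compound 2, and the step from compound 2 to compound 3 is estimated at a 1.3-fold lower number from compound 2 to compound 3 (0.10 log units; within the scatter). The estimate for compound 3 in this assay is 900 nM, with a range from 300 nM to 3000 nM.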

Compound 3, half-maximal inhibitory concentration: 780 nM
For compound 3 the middle estimate is 1.2-fold (0.06 log units) above the measured one; the range from low to high includes it.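

In this assay, among these compounds, placing 2,4-difluorophenyl where 4-methylphenyl stood gives a 1.5-fold lower number from compound 2 to compound 3 (0.16 log units; within the scatter) on the six-membered aromatic ring with 2 nitrogen, and this is the first measured step at this position. It shows that, in this pair, exchanging the methyl for two fluorines on the phenyl ring leaves the reading indistinguishable from repeat-measurement noise; both groups hold one six-membered aromatic ring of carbon only, with no hydrogen-bond donors or acceptors and no net charge. No measured information here accounts for this outcome.

Going by these compounds, the two groups compared are close relatives, so it stays open whether a group of another kind at this place, such as a carboxylic acid, an amine or a morpholine ring, would shift the number beyond the scatter. Also open, on these data alone, is how a phenyl ring with a single fluorine would compare with compound 2 and compound 3, so this one pair cannot yet separate the contributions of the two fluorines or of the lost methyl.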